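A few compounds are considered here, and "the series" means these few. Any claim that something is new, unique, unknown or untested is made for them only; others in the source may bear on it.

Measured compounds in a functional assay on DU-145 cells (Homo sapiens) for cytotoxicity, read by CCK-8 assay, with a stated time of 4 days; a lower number here means a stronger inhibitor, a higher number a weaker inhibitor:
compound 1 `Oc1ccc(-c2cc(-c3ccc(O)cc3)nc(-c3ccc(O)cc3)c2)cc1` gives 3160 nM
compound 2 `Oc1ccc(-c2cc(-c3ccc(O)cc3)nc(-c3ccccc3O)c2)cc1` sits at the assay limit > 50000 nM
compound 3 `Oc1ccc(-c2cc(-c3ccccc3O)nc(-c3ccccc3O)c2)cc1` also sits at the assay limit > 50000 nM

Among the compounds with values here, compound 1 holds the only number in this assay; the other two entries are limits, and the limit of > 50000 nM in this assay, at which 2 of the 3 values shown sit, is where both of them lie. Within the data shown here, the one readable step is an at least 15-fold higher number from compound 1 to compound 2 (1.19 log units; beyond the scatter), where a 2-hydroxyphenyl took the place of a 4-hydroxyphenyl. The further move, a step that the two limits leave unreadable from compound 2 to compound 3, cannot be sized.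

Compound 4 `Oc1ccc(-c2cc(-c3cccc(O)c3)cc(-c3ccc(O)cc3)n2)cc1` differs from compound 1 by 3-hydroxyphenyl in place of 4-hydroxyphenyl on an aromatic carbon. Among the measured compounds shown here, no measured pair moves a hydroxyl to the 3-position, so the step from compound 1 to compound 2 is the nearest guide, and it shows that leaving the 4-hydroxyphenyl pattern carried a large loss. A shift to 3-hydroxyphenyl, at a different position on the shared core, is expected to cost less but still to raise the number beyond the scatter. The step for compound 4 is estimated as a 3.8-fold higher number from compound 1 to compound 4 (0.58 log units; beyond the scatter). Compound 4 is therefore estimated at 12000 nM, within 3000 nM to 50000 nM, with a real chance that only a limit is returned.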

Compound 4, half-maximal inhibitory concentration: 1400 nM
The estimate for compound 4 lay 8.6-fold (0.93 log units) above the measured number; measured number below the stated range.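

In this assay, the place opposite the ring nitrogen accepts 3-hydroxyphenyl in place of 4-hydroxyphenyl, with a 2.3-fold lower number from compound 1 to compound 4 (0.35 log units; beyond the scatter), so the 4-hydroxyphenyl group is not required there. Within the data shown here, until now the only readable change from 4-hydroxyphenyl, the one to 2-hydroxyphenyl, raised the number; this step shows that leaving 4-hydroxyphenyl does not always carry a loss, with compound 2 as the case that goes the other way. Nothing shown gives a cause for the modest gain.

Still open, from the compounds shown here alone, is whether the hydroxyl is needed at all at this place, and whether 2-hydroxyphenyl would be tolerated here. An aminophenyl or a methoxyphenyl group at the same place, or 3-hydroxyphenyl on the other two positions of the shared core, could show how far this gain extends.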